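The compounds below may be only part of what the source reports. "The series", "measured", "known", "first", "only" and "open" are said of these compounds alone.

Notes on the series in a functional assay on MCF7 cells (Homo sapiens) for antiproliferative activity, read by MTT assay, with a stated time of 72 h; a higher number here means a weaker inhibitor, a lower number a stronger inhibitor: compound 1 (`CNC(=O)c1cc(Oc2ccc(NC(=O)c3nn(-c4ccccc4Cl)c(=O)cc3C)cc2F)ccn1`) gives 136000 nM, compound 2 (`CCCNC(=O)c1cc(Oc2ccc(NC(=O)c3nn(-c4ccccc4OC(F)(F)F)c(=O)cc3C)cc2F)ccn1`) gives 7420 nM, and compound 3 (`CCCNC(=O)c1cc(Oc2ccc(NC(=O)c3nn(-c4cccc(C(F)(F)F)c4)c(=O)cc3C)cc2F)ccn1`) gives 30000 nM. Compound 3 therefore sits in the middle of the three numbers.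

The next compound is compound 4 (`CNC(=O)c1cc(Oc2ccc(NC(=O)c3nn(-c4cccc(C(F)(F)F)c4)c(=O)cc3C)cc2F)ccn1`), which differs from compound 3 at one place: hydrogen in place of ethyl on a saturated chain carbon bound to an amide-type nitrogen. In words, this is hydrogen in place of ethyl on a saturated chain carbon bound to an amide-type nitrogen, or propylcarbamoyl to methylcarbamoyl.

Among the compounds with values here, the only measured step is a 4.0-fold higher number from compound 2 to compound 3 (0.61 log units; beyond the scatter). It is modest and beyond the scatter, but it concerns the group on the aromatic nitrogen, so it bears on the chain change only as a guide to size. The nearest evidence is compound 1, which carries the methylcarbamoyl group and has the highest number at 136000 nM. Compound 1 also differs from compound 3 in the aromatic group on nitrogen, so its gap cannot be assigned to the chain alone. Within the data shown here, no measured pair isolates the chain change.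

A modest step towards a higher number is expected, no larger than about the measured one. The estimated step is a 2.2-fold higher number from compound 3 to compound 4 (0.34 log units; beyond the scatter). For compound 4 the expected value is 65000 nM, with an estimated range of 20000 nM to 200000 nM.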

Compound 4, half-maximal inhibitory concentration: 45800 nM
For compound 4 the middle estimate is 1.4-fold (0.15 log units) above the measured one; measured number inside the range.
By their numbers in this assay, from the lowest: compound 2; then compounds 3 and 4 (each within the scatter of the next); then compound 1.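

In this assay, the step from propylcarbamoyl to methylcarbamoyl is a 1.5-fold higher number from compound 3 to compound 4 (0.18 log units; within the scatter), so with 3-(trifluoromethyl)phenyl on the aromatic nitrogen, replacing ethyl with hydrogen at this chain position does not separate the pair. With methylcarbamoyl held fixed, the group on the aromatic nitrogen does separate a pair: 3-(trifluoromethyl)phenyl in place of 2-chlorophenyl gives a 3.0-fold lower number from compound 1 to compound 4 (0.47 log units; beyond the scatter), which places the high number of compound 1 with its 2-chlorophenyl group in this one-place comparison, not with its chain. No measurement in hand accounts for either step.

The compounds shown leave open whether the chain change would also stay within the scatter with 2-chlorophenyl or 2-(trifluoromethoxy)phenyl on the aromatic nitrogen, since the only chain pair here carries 3-(trifluoromethyl)phenyl. They also leave open how a longer chain such as hexyl, a cyclopropyl group or a chain ending in a hydroxyl or an amine would read in this assay in place of propyl or methyl.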